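The source may report more compounds than this note shows. Statements on the series, on what has been measured and on what is new or still open speak of the compounds shown alone.

Working notes on the aminothiophene ketone series, the aryl group on the ring amine being the variable.

Among the measured compounds shown here, compound 3 `Nc1scc(CN2CCN(c3ccccc3F)CC2)c1C(=O)c1ccc(Cl)cc1` holds the highest of the three numbers so far in a functional assay on CHO cells with adenosine receptor A1 (Homo sapiens) as the target, read by cAMP accumulation and immunoassay, with a stated time of 6 min, tested at 1 uM (on this read-out lower numbers stand for a stronger effect and higher numbers for a weaker effect at the one concentration tested), where compound 3 gives -9.2%. Compound 1 `COc1ccc(N2CCN(Cc3csc(N)c3C(=O)c3ccc(Cl)cc3)CC2)cc1` is nearest, giving -15% in this assay, and the step of a number 5.8 percentage points higher from compound 1 to compound 3 (within the scatter) is within the scatter, so the two are not ordered against each other. Compound 2 `Nc1scc(CN2CCN(c3ccccc3C(F)(F)F)CC2)c1C(=O)c1ccc(Cl)cc1` is furthest, giving -39% in this assay, and the step of a number 29.8 percentage points higher from compound 2 to compound 3 (beyond the scatter) lies beyond the scatter. The remaining step, a number 24 percentage points lower from compound 1 to compound 2 (beyond the scatter), is likewise beyond the scatter.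

Compound 4 `Nc1scc(CN2CCN(c3cccc(F)c3F)CC2)c1C(=O)c1ccc(Cl)cc1` differs from compound 3 by fluoro in place of hydrogen on an aromatic carbon.

Of the measured steps, both that bear on the aryl group apply here: a trifluoromethyl in place of fluoro moved the number beyond the scatter, whereas exchanging one aryl for another of comparable size did not. A single added fluoro is a smaller change than either, so no step beyond the scatter is expected, with a slight lean toward a lower number.

For compound 4 the expected step in this assay is a number 4.8 percentage points lower from compound 3 to compound 4 (within the scatter), and the estimate for compound 4 is -14%, within -34% to 6%.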

Compound 4, a percentage reported as activity, at one concentration (the size of the read-out at that concentration, not a potency): -66%
Compound 4: middle estimate off by 52 percentage points, on the high side; the whole stated range lies above it.
By their numbers in this assay, from the lowest: compound 4; then compound 2; then compounds 1 and 3 (each within the scatter of the next).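

The added fluoro is one heavy atom on an aromatic carbon, ortho to a fluoro group, yet it gives a number 56.8 percentage points lower from compound 3 to compound 4 (beyond the scatter) in this assay, so this position on the aryl ring responds strongly to a very small change, which the earlier aryl exchanges could not show. The 2,3-difluorophenyl group also separates from both earlier aryl groups, with a number 27 percentage points lower from compound 2 to compound 4 (beyond the scatter) and a number 51 percentage points lower from compound 1 to compound 4 (beyond the scatter), so among these compounds the lowest number does not require a group as large as trifluoromethyl. Nothing available explains why this one fluoro carries so large a step.

Open, on these data alone, is whether the step depends on the two fluoro groups together or on the new fluoro alone, which a 3-fluorophenyl compound would address, and whether chloro, methyl, methoxy or nitrile on the same aromatic carbon would behave as fluoro does. With one read-out at one concentration, the compounds shown also leave open how the step would appear across a range of concentrations.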